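From an Isopentyl Chain to a Cyclohexyl Ring

A few compounds are considered here, and "the series" means these few. Any claim that something is new, unique, unknown or untested is made for them only; others in the source may bear on it.

Compound 1 `CC(C)CCCOc1cccc(O)c1C(=O)/C=C/c1ccc(O)cc1`: 11600 nM
Compound 2 `CC(C)=CCOc1cccc(O)c1C(=O)/C=C/c1ccc(O)cc1`: > 30000 nM
Compound 3 `O=C(/C=C/c1ccc(O)cc1)c1c(O)cccc1OCC1CCCCC1`: not yet measured

For the measured compounds named here, in a functional assay on HCT-15 cells (Homo sapiens) for antiproliferative activity, read by sulforhodamine B assay (a higher number here means a weaker inhibitor of growth, a lower number a stronger inhibitor of growth), compound 1 gives 11600 nM, the only exact number so far. Compound 2 gives > 30000 nM, which is a limit of the assay and not a number. Going by the values given here, the one measured step, an at least 2.5-fold higher number from compound 1 to compound 2 (0.41 log units; beyond the scatter), lies beyond the scatter, but it brings a different group. Compound 3 carries cyclohexyl in place of isopentyl on a saturated chain carbon bound to an oxygen on an aromatic ring, cyclohexyl in place of isopentyl on a saturated chain carbon bound to an oxygen on an aromatic ring. Among the compounds with values here, with only that step as a guide, no change beyond the scatter is expected in this assay. The expected step is a 1.0-fold higher number from compound 1 to compound 3 (0.01 log units; within the scatter). For compound 3 the estimated value is 12000 nM, with an expected range of 5000 nM to 30000 nM.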

Compound 3, concentration for 50% growth inhibition: > 30000 nM
Compound 3: no number, only a limit (the forecaster's own chance of this, stated with the estimate: 20%); middle value at least 2.5-fold (0.39 log units) away from the limit.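

In this assay, cyclohexyl in place of isopentyl gives an at least 2.5-fold higher number from compound 1 to compound 3 (0.41 log units; beyond the scatter), so a second change at this place, this time one that brings a ring, also moves the number beyond the scatter. Compound 3 gives > 30000 nM, which is a limit of the assay and not a number. The step between compound 2 and compound 3 cannot be read, because both values are limits: the limit of > 30000 nM in this assay, at which 2 of the 3 values shown sit.

On these data alone, whether a longer chain, or an amine or a carboxylic acid at the end of the chain, would give a lower number than compound 1 stays open.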